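From acetoxy to dimethylamino on a shared core

The source may report more compounds than this note shows. Statements on the series, on what has been measured and on what is new or still open speak of the compounds shown alone.

Measured in a functional assay on MCF7 cells (Homo sapiens) for antiproliferative activity, read by MTT assay, with a stated time of 48 h; on this read-out higher numbers stand for weaker inhibition and lower numbers for stronger inhibition
- compound 1 `CC(=O)OC/C1=C/C[C@](C)(CCC=C(C)C)/C=C/[C@@H](OC(=O)C=C(C)C)[C@](C)(O)/C=C/C1=O` gives 4510 nM
- compound 2 `CC(=O)O[C@]1(C)/C=C/C(=O)/C(CO)=C\C[C@](C)(CCC=C(C)C)/C=C/[C@H]1OC(=O)C=C(C)C` gives 2320 nM

Going by the values given here, compound 1, at 4510 nM, and compound 2, at 2320 nM, lie within the scatter of each other, so compound 1 stands level with the only other measured compound. Compound 3 `CC(C)=CCC[C@]1(C)/C=C/[C@@H](OC(=O)C=C(C)C)[C@](C)(O)/C=C/C(=O)/C(CN(C)C)=C\C1` has not yet been measured. It differs from compound 1 by a single change, dimethylamino in place of acetoxy on a saturated chain carbon bound to a double-bonded ring carbon. Among the compounds with values here, no measured pair shows this change, so the data offer no direct guide to its size or direction. The expected outcome in this assay is a 1.3-fold lower number from compound 1 to compound 3 (0.11 log units; within the scatter), which means no step beyond the scatter is anticipated. For compound 3 the estimated value is 3500 nM, with an expected range of 1200 nM to 10000 nM.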

Compound 3, half-maximal inhibitory concentration: 690 nM
Estimate against measurement, compound 3: 5.1-fold (0.71 log units) above, outside the stated range (below it).
By their numbers in this assay, from the lowest: compound 3; then compounds 2 and 1 (each within the scatter of the next).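

In this assay, replacing acetoxy with dimethylamino on a saturated chain carbon bound to a double-bonded ring carbon gives a 6.5-fold lower number from compound 1 to compound 3 (0.82 log units; beyond the scatter). Going by these compounds alone, this is the first measured pair to vary this position, and it shows that the group held there can move the number beyond the scatter. The change is small in atom count, with four heavy atoms leaving and three entering, and no measurement on these compounds accounts for the drop. 

As far as these compounds go, it remains open whether the step belongs to dimethylamino itself or would also appear with another amine on the same carbon, such as pyrrolidine or a primary amine. Also open, from the compounds shown here alone, is whether the same exchange would give a step of like size on the core of compound 2.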